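A Methyl for a Methoxy on the Amide Aryl

This account rests on a few compounds, and the source may have more. Where it says the series, first, only, none or still open, it means among the compounds named here.

Three measured compounds share one core and differ only in the aryl group attached to the amide carbonyl. Compound 1 `O=C(Nc1cc(Sc2ncn[nH]2)c(O)c2ccccc12)c1ccc([N+](=O)[O-])cc1` gives 53500 nM in a functional assay on PC-3 cells (Homo sapiens) for antiproliferative activity, read by MTT assay, with a stated time of 48 h; on this read-out higher numbers stand for weaker inhibition and lower numbers for stronger inhibition. Compound 2 `O=C(Nc1cc(Sc2ncn[nH]2)c(O)c2ccccc12)c1cccc([N+](=O)[O-])c1` gives 26900 nM in this assay, a change of a 2.0-fold lower number from compound 1 to compound 2 (0.30 log units; within the scatter). Compound 3 `COc1ccc(C(=O)Nc2cc(Sc3ncn[nH]3)c(O)c3ccccc23)cc1` reaches only the limit of this assay, > 100000 nM. The steps of an at least 1.8-fold higher number from compound 1 to compound 3 (0.27 log units; that floor lies within the scatter) and an at least 3.7-fold higher number from compound 2 to compound 3 (0.57 log units; beyond the scatter) both lead into compound 3, whose true number is therefore known only as that limit. Compound 4 `Cc1cccc(C(=O)Nc2cc(Sc3ncn[nH]3)c(O)c3ccccc23)c1` carries 3-methylphenyl in place of 4-methoxyphenyl on a carbonyl carbon. Among the measured compounds shown here, no measured step exchanges a methoxy for a methyl, and the two steps into compound 3 give only the starting point. Compound 4 is expected to stay near that limit, a step of a number no higher from compound 3 to compound 4 (the limit leaves the size open). The estimate for compound 4 is 100000 nM, between 30000 nM and 300000 nM.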

Compound 4, half-maximal inhibitory concentration: 59500 nM
Compound 4: middle estimate off by 1.7-fold (0.23 log units), on the high side, and the stated range covers the measured number.
By their numbers in this assay, from the lowest: compounds 2, 1 and 4 (each within the scatter of the next, the first and the last beyond it). At a limit, above all of these: compound 3.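

The step of an at least 1.6-fold lower number from compound 3 to compound 4 (0.22 log units; that floor lies within the scatter) stays open in size because compound 3 is held at a limit: the limit of > 100000 nM in this assay, at which 1 of the 4 values shown sits.
In this assay the step of a 2.2-fold higher number from compound 2 to compound 4 (0.34 log units; beyond the scatter) shows that methyl in place of nitro costs a modest amount of activity at this place on the aryl ring. The step of a 1.1-fold higher number from compound 1 to compound 4 (0.05 log units; within the scatter) shows no real separation, so 3-methylphenyl and 4-nitrophenyl read alike here.

As far as these compounds go, what an amine or a carboxylic acid on this aryl group would do remains open.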